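The compounds below may be only part of what the source reports. "The series", "measured", "known", "first", "only" and "open" are said of these compounds alone.

Measured in an ADME assay on HEK-293T cells (Homo sapiens) for cytotoxicity, read by luminescence, with a stated time of 24 h; on this read-out higher numbers stand for lower toxicity in this test and lower numbers for higher toxicity in this test:
- Compound 1 `COc1ccc(Cn2c(C(=O)N3CCC(C(=O)O)CC3)cc3sccc32)cc1`: > 100000 nM, a limit.
- Compound 2 `COc1ccc(Cn2c(C(=O)N3CCC(C(=O)NC(C)c4ccccc4)CC3)cc3sccc32)cc1`: > 100000 nM, a limit.
- Compound 3 `CCCNC(=O)C1CCN(C(=O)c2cc3sc(C(=O)c4ccccc4)cc3n2Cc2ccc(OC)cc2)CC1`: > 100000 nM, a limit.

Compound 3 has no number of its own and stands with the other two at the limit of > 100000 nM in this assay, at which 3 of the 3 values shown sit. Compound 4 `CCCNC(=O)C1CCN(C(=O)c2cc3sc(CO)cc3n2Cc2ccc(OC)cc2)CC1` carries hydroxymethyl in place of benzoyl on an aromatic carbon. Among the compounds with values here, the only measured step, a step that the two limits leave unreadable from compound 1 to compound 2, lies at another place and offers no size to carry over. The expectation therefore rests on compound 3, whose limit is > 100000 nM. The estimated change is a number no higher from compound 3 to compound 4 (the limit leaves the size open), with no shift expected beyond the scatter in either direction. Compound 4 is estimated at 100000 nM, with an expected range of 50000 nM to 200000 nM, and it will most likely be reported only as a limit.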

Compound 4, half-maximal cytotoxic concentration: 15500 nM
Compound 4: middle estimate off by 6.5-fold (0.81 log units), on the high side; the measured number lies below the stated range.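

In this assay, hydroxymethyl in place of benzoyl on the aromatic carbon next to the ring sulfur gives an at least 6.4-fold lower number from compound 3 to compound 4 (0.80 log units; beyond the scatter), so a change at this position can register in this read-out, towards higher toxicity in this test. The earlier steps cannot be read, and the earlier compounds gave no number at all: the limit of > 100000 nM in this assay, at which 3 of the 4 values shown sit.

This pair does not separate the loss of benzoyl from the arrival of hydroxymethyl. A methyl, a carboxylic acid or an aminomethyl group at this position would bear on that question.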